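Replacing the Methylcarbamoyl Group of Compound 1

The compounds below may be only part of what the source reports. "The series", "measured", "known", "first", "only" and "open" are said of these compounds alone.

Compound 1 `CNC(=O)C1=CC(C)(CF)Oc2ccc([N+](=O)[O-])cc21` is one of three measured compounds sharing a common core, the others being compound 2 `CNC(=O)C1=CC(CF)(CF)Oc2ccc([N+](=O)[O-])cc21` and compound 3 `CNC(=O)C1=CC(C)(C(F)(F)F)Oc2ccc([N+](=O)[O-])cc21`. In a functional assay on the whole organism (aorta) with Rattus norvegicus as the target (on this read-out lower numbers stand for smaller maximal responses and higher numbers for larger maximal responses), compound 1 gives 66%, compound 2 gives 70.7% and compound 3 gives 61.7%. Compound 1 thus stands second highest of the three, with compound 3 nearest and compound 2 furthest, and both steps, a number 4.7 percentage points higher from compound 1 to compound 2 (within the scatter) and a number 4.3 percentage points lower from compound 1 to compound 3 (within the scatter), lie within the scatter.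

Compound 4 `CC1(CF)C=C(/C(S)=N\CCC#N)c2cc([N+](=O)[O-])ccc2O1` has not been measured in this assay. It differs from compound 1 as follows: a group of 7 heavy atoms (4 carbon, 2 nitrogen, 1 sulfur; no ring) in place of a group of 4 heavy atoms (2 carbon, 1 nitrogen, 1 oxygen; no ring), on a double-bonded ring carbon. Neither measured step bears on this change, since both alter the groups on the saturated ring carbon and leave the methylcarbamoyl group untouched; they only show that the core tolerates small variation at that carbon without a step beyond the scatter. The data therefore give no direct guide for the group entering at the double-bonded ring carbon, and a wide range is appropriate.

The estimate for compound 4 in this assay is 60%, expected to fall between 35% and 85%, which corresponds to an expected step of a number 6 percentage points lower from compound 1 to compound 4 (within the scatter).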

Compound 4, intrinsic activity: the largest response reached, in percent of the reference agonist's: 59.6%
For compound 4 the middle estimate is 0.4 percentage points above the measured one; low and high end bracket the measured number.
By their numbers in this assay, from the lowest: compounds 4, 3, 1 and 2 (each within the scatter of the next, the first and the last beyond it).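

In this assay, putting the group of 7 heavy atoms (4 carbon, 2 nitrogen, 1 sulfur) in place of methylcarbamoyl on the double-bonded ring carbon gives a number 6.4 percentage points lower from compound 1 to compound 4 (within the scatter) for this exchange, the first reading at this position among the compounds shown. The earlier steps shown here all concerned the saturated ring carbon, whereas this one shows that, in this single comparison, the methylcarbamoyl group can be exchanged for a group with more heavy atoms, a sulfur atom and a triple bond without a step beyond the scatter. Nothing measured here speaks to why the maximal response of compound 4 remains within the scatter of that of compound 1.

The entering group differs from methylcarbamoyl in its sulfur atom and its nitrile-bearing chain at the same time, so the compounds shown do not separate the contribution of either part. Within the data shown here, they also leave open how a carboxylic acid, an amine or a ring-bearing group on the double-bonded ring carbon would read out, and whether a group with a longer or shorter chain than the one in compound 4 would stay within the scatter.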